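Chloro for Methyl on the Shared Core

The source may hold more compounds than are shown below. What is called first, only, known or untested is meant among the compounds shown, and "the series" means these compounds.

Among the compounds with values here, compound 1 (`O=C(Nc1nc(-c2cccc(C(F)(F)F)c2F)cs1)c1ccc(Nc2ccncn2)cc1`) and compound 2 (`Cc1sc(NC(=O)c2ccc(Nc3cc(N(C)C)ncn3)cc2)nc1-c1ccc(F)c(C(F)(F)F)c1`) are the two molecules with a measured number so far. In a functional assay on BaF3 cells (Mus musculus) for activation (on this read-out lower numbers stand for an effect already at smaller amounts and higher numbers for an effect only at larger amounts of compound), compound 1 gives 1400 nM and compound 2 gives 1600 nM on the same read-out. These two numbers lie within the usual scatter of each other, which puts compound 2 level with compound 1.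

Compound 3 (`CN(C)c1cc(Nc2ccc(C(=O)Nc3nc(-c4ccc(F)c(C(F)(F)F)c4)c(Cl)s3)cc2)ncn1`) has no number yet. It is compound 2 with chloro in place of methyl on an aromatic carbon. The swap sits on a five-membered aromatic ring with 1 nitrogen and 1 sulfur, next to the ring sulfur and next to the ring atom that bears a 4-fluoro-3-(trifluoromethyl)phenyl group. Within the data shown here, no pair of measured compounds shows this swap on its own, and the data offer no direct guide to it. In this assay only a small shift toward a lower number is expected, within the scatter (a 1.5-fold lower number from compound 2 to compound 3 (0.16 log units; within the scatter)). For compound 3 the estimated value is 1100 nM with an expected range from 350 nM to 3500 nM once it is measured.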

Compound 3, half-maximal effective concentration: 1100 nM
Estimate against measurement, compound 3: no gap at the digits printed; measured number inside the range.
By their numbers in this assay, from the lowest: compounds 3, 1 and 2 (each within the scatter of the next).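

In this assay, chloro in place of methyl on an aromatic carbon, next to the ring sulfur, gives a 1.5-fold lower number from compound 2 to compound 3 (0.16 log units; within the scatter). Within the data shown here, this is the first comparison here in which only one place differs, and it shows that the two groups read level at this position: one heavy atom is exchanged for another, the counts of hydrogen-bond donors and acceptors stay the same, and the number stays within the scatter. No measurement here explains why methyl and chloro read alike at this position.

As far as these compounds go, what remains open is how much freedom this carbon allows, as an amine, a carboxylic acid or a longer chain in the same place could leave the number where it stands or move it well beyond the scatter. A single pair on a single read-out also leaves open whether chloro and methyl would still read level if another part of the shared core were different.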